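From bromophenyl to methylphenyl in the amide arm

The source may hold more compounds than are shown below. What is called first, only, known or untested is meant among the compounds shown, and "the series" means these compounds.

Measured compounds in a functional assay on GTL 16 cells for antiproliferative activity against GTL 16 cell line (Homo sapiens), read by CCK-8 assay, with a stated time of 72 h; on this read-out higher numbers stand for weaker inhibition and lower numbers for stronger inhibition:
compound 1 `COc1ccc(C(=O)Nc2cccc(-c3oc4cc(-c5ccc(F)cc5)ccc4c(=O)c3O)c2)cc1` gives 21100 nM
compound 2 `COc1ccccc1C(=O)Nc1cccc(-c2oc3cc(-c4ccc(F)cc4)ccc3c(=O)c2O)c1` gives 6370 nM
compound 3 `O=C(Nc1cccc(-c2oc3cc(-c4ccc(F)cc4)ccc3c(=O)c2O)c1)c1ccc(Br)cc1` gives 25400 nM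

Compound 3 carries the highest number of the three in this assay. Its nearest neighbour is compound 1, reached by the step of a 1.2-fold higher number from compound 1 to compound 3 (0.08 log units; within the scatter), which lies within the scatter; its furthest is compound 2, since a 4.0-fold higher number from compound 2 to compound 3 (0.60 log units; beyond the scatter) is beyond the scatter, as is a 3.3-fold lower number from compound 1 to compound 2 (0.52 log units; beyond the scatter).

Compound 4 `Cc1cccc(C(=O)Nc2cccc(-c3oc4cc(-c5ccc(F)cc5)ccc4c(=O)c3O)c2)c1` differs from compound 3 by 3-methylphenyl in place of 4-bromophenyl on a carbonyl carbon. Among the measured compounds shown here, the steps that bear on this are the two that change the aryl group on the carbonyl carbon: the 2-methoxyphenyl of compound 2 gives a modestly lower number than either 4-methoxyphenyl or 4-bromophenyl, while those two are within the scatter of each other. A 3-methylphenyl has no direct precedent among these compounds, so a modest move towards lower numbers in this assay is expected, but not confidently. Compound 4 is therefore estimated at 14000 nM, within 4500 nM to 45000 nM, a step of a 1.8-fold lower number from compound 3 to compound 4 (0.26 log units; within the scatter) from compound 3, which is expected rather than known.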

Compound 4, half-maximal inhibitory concentration: 10900 nM
Beside the measured number, compound 4's estimate is 1.3-fold (0.11 log units) above it; measured number inside the range.
By their numbers in this assay, from the lowest: compounds 2, 4, 1 and 3 (each within the scatter of the next, the first and the last beyond it).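

In this assay, placing 3-methylphenyl on the carbonyl carbon in place of 4-bromophenyl gives a 2.3-fold lower number from compound 3 to compound 4 (0.37 log units; beyond the scatter), so an aryl group other than 2-methoxyphenyl now also separates from 4-bromophenyl beyond the scatter. The other two steps stay within the scatter, a 1.7-fold higher number from compound 2 to compound 4 (0.23 log units; within the scatter) and a 1.9-fold lower number from compound 1 to compound 4 (0.29 log units; within the scatter), so 3-methylphenyl cannot be ranked against either methoxyphenyl group, even though those two differ from each other beyond the scatter. No measurement here explains why the aryl groups differ at this position.

The step from compound 3 changes both the substituent and its place on the ring, and these compounds do not separate those two changes. Going by these compounds, it also remains open how an amine or a carboxylic acid on this aryl group would read in this assay.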